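Swapping a bicyclic amine for pyrrolidine on a shared core

The compounds below may be only part of what the source reports. "The series", "measured", "known", "first", "only" and "open" are said of these compounds alone.

Compound 1 `c1ccc2c(c1)CCN(c1ccnc(Nc3ccc(Oc4ncnc5ccsc45)cc3)n1)C2` carries a 1,2,3,4-tetrahydroisoquinolin-2-yl group on its core. In a functional assay on HCT-116 cells (Homo sapiens) for inhibition, read by MTT assay, with a stated time of 72 h, tested at 20 uM (a higher number here means more inhibition at the concentration tested (going by the name of the read-out), a lower number less inhibition), compound 1 gives 40.9%, the highest of the three numbers measured. Compound 2 `c1ccc2c(c1)CCN(c1ccnc(Nc3ccc(Oc4ncnc5sccc45)cc3)n1)C2` gives 18.1%, and compound 3 `CNC(=O)c1cc(Oc2ccc(Nc3nccc(N4CCc5ccccc5C4)n3)cc2)ccn1` gives 31.2%. The step of a number 22.8 percentage points lower from compound 1 to compound 2 (beyond the scatter) and the step of a number 13.1 percentage points higher from compound 2 to compound 3 (beyond the scatter) both lie beyond the scatter, while the step of a number 9.7 percentage points lower from compound 1 to compound 3 (within the scatter) lies within it; all three steps change only the group on the oxygen.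

Compound 4 `c1cc(N2CCCC2)nc(Nc2ccc(Oc3ncnc4ccsc34)cc2)n1` is not yet measured. It differs from compound 1 in one place: pyrrolidin-1-yl in place of 1,2,3,4-tetrahydroisoquinolin-2-yl on an aromatic carbon. Within the data shown here, none of the measured steps touches this position, so no measured step bears directly on the change; the three steps together show that the numbers in this assay move over a modest range when a group of similar size is exchanged elsewhere. For a change that replaces the 1,2,3,4-tetrahydroisoquinolin-2-yl group with the smaller pyrrolidin-1-yl group, a modest loss seems the more likely outcome, although a step within the scatter cannot be ruled out. The estimate for compound 4 in this assay is 30%, with a range from 12% to 48%, which means an expected step of a number 10.9 percentage points lower from compound 1 to compound 4 (beyond the scatter).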

Compound 4, a percentage reported as inhibition, at one concentration (the size of the read-out at that concentration, not a potency): 22.2%
Estimate against measurement, compound 4: 7.8 percentage points above, within the range that was stated.
By their numbers in this assay, from the lowest: compounds 2, 4, 3 and 1 (each within the scatter of the next, the first and the last beyond it).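

Among these compounds, the earlier compounds changed only the group on the oxygen, so this is the first reading at the aromatic carbon next to the ring nitrogen. In this assay, pyrrolidin-1-yl in place of 1,2,3,4-tetrahydroisoquinolin-2-yl gives a number 18.7 percentage points lower from compound 1 to compound 4 (beyond the scatter), which shows that the group at this position also affects the read-out, while the two groups match in hydrogen-bond donors, hydrogen-bond acceptors and net charge. No available measurement explains why the number falls, and this single pair cannot separate the loss of the six-membered aromatic ring of carbon only from the smaller size of the entering group.

Piperidin-1-yl, which has a six-membered non-aromatic ring but no fused aromatic ring, or morpholin-4-yl, which adds a ring oxygen, could help to separate those two differences. Among the compounds shown here, it also remains open whether the same exchange would give a similar step with the group on the oxygen found in compound 2 or the one found in compound 3, since pyrrolidin-1-yl appears here only with the group on the oxygen found in compound 1.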